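Swapping Iodo for Fluoro Across Two Different Cores

The source may hold more compounds than are shown below. What is called first, only, known or untested is meant among the compounds shown, and "the series" means these compounds.

Of the compounds shown here, three have been measured in an assay on isolated protein for inhibition of Calpain-1 catalytic subunit (Sus scrofa); a higher number here means a weaker inhibitor, a lower number a stronger inhibitor. Compound 1 `O=C(O)/C(S)=C/c1c[nH]c2c(F)cccc12` and compound 2 `O=C(O)/C(S)=C/c1c[nH]c2c(I)cccc12` share one core and differ only in a single halogen on it. In this assay compound 1 gives 110 nM, while compound 2 gives 220 nM. The change between them, (fluoro in place of iodo on an aromatic carbon), gave a 2.0-fold lower number from compound 2 to compound 1 (0.30 log units; within the scatter), so the two halogens on this core are not told apart here.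

Compound 3 `O=C(O)/C(S)=C/c1ccccc1I` carries the same acid-bearing side chain on a different core. In this assay compound 3 gives 42800 nM, the highest of the three numbers. How the core of compound 3 differs from the core of compound 2 is not broken down here; the two values alone show a large gap between them.

Compound 4 `O=C(O)/C(S)=C/c1ccccc1F` has not yet been measured. It differs from compound 3 by fluoro in place of iodo on an aromatic carbon. For the measured compounds named here, this is the same kind of change as the one from compound 2 to compound 1, but not the same: on the core of compound 1 the changed carbon is part of a fused or bridged system of two rings, ortho to a fused ring and meta to a fused ring, whereas on the core of compound 3 it sits on a six-membered aromatic ring of carbon only, ortho to a group of 6 heavy atoms.

Resting on the step from compound 2 to compound 1, which was a 2.0-fold lower number from compound 2 to compound 1 (0.30 log units; within the scatter), the step to compound 4 is expected to be a 1.7-fold lower number from compound 3 to compound 4 (0.23 log units; within the scatter). Compound 4 is therefore estimated to give 25000 nM in this assay, with a range from 8000 nM to 80000 nM.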

Compound 4, half-maximal inhibitory concentration: 23200 nM
Estimate against measurement, compound 4: 1.1-fold (0.03 log units) above; the range from low to high includes it.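

In this assay the swap of iodo for fluoro on the core of compound 3 gave a 1.8-fold lower number from compound 3 to compound 4 (0.27 log units; within the scatter), so on this core, as on the core of compound 1, the two halogens are not told apart. Set side by side, the two steps show no difference between the cores: the same change on two cores in this assay, a 2.0-fold lower number (0.30 log units; within the scatter) from compound 2 to compound 1 and a 1.8-fold lower number (0.27 log units; within the scatter) from compound 3 to compound 4, 1.1-fold (0.04 log units) apart, within the scatter of two such steps

Within these two pairs, then, the change carries from one core to the other, even though the changed carbon sits in a different setting on each core and the cores themselves stand far apart in their values. For the compounds shown here, this does not show a rule for other cores, since it rests on only two pairs, and because neither step rises beyond the scatter, it also does not show that a clear effect of this change would carry over.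

As far as these compounds go, the changed carbon bears only iodo or fluoro in these compounds, so it remains open whether a chloro, methyl or methoxy group there would also match across the two cores. All four compounds also keep the same acid-bearing side chain, which leaves open whether the match would hold with an ester or an amide in place of the carboxylic acid.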